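From compound 3 to its ethoxy counterpart, compound 4

The source may hold more compounds than are shown below. What is called first, only, known or untested is meant among the compounds shown, and "the series" means these compounds.

Of the compounds shown here, three sharing one core have been measured in a functional assay, with a stated time of 10 min; a lower number here means a stronger inhibitor, a higher number a weaker inhibitor. Compound 1 (`O=c1cc(/C=C/c2ccccc2)[nH]cc1O`) gives 4030 nM, compound 2 (`CCOc1ccc(/C=C/c2cc(=O)c(O)c[nH]2)cc1`) gives 8120 nM, and compound 3 (`Cn1cc(O)c(=O)cc1/C=C/c1ccccc1`) gives 2110 nM. Compound 3 has the lowest number of the three, but it stands clearly apart only from compound 2, since compound 1 lies within the scatter of it.

Compound 4 (`CCOc1ccc(/C=C/c2cc(=O)c(O)cn2C)cc1`) has not yet been measured. It differs from compound 3 in one place: ethoxy in place of hydrogen on an aromatic carbon. This is ethoxy in place of hydrogen on an aromatic carbon. Among the compounds with values here, two measured steps bear on this change. Within the data shown here, the same replacement appears in a 2.0-fold higher number from compound 1 to compound 2 (0.30 log units; within the scatter), the only direct precedent. The methyl on the aromatic nitrogen, which compound 3 and compound 4 share, appears in a 1.9-fold lower number from compound 1 to compound 3 (0.28 log units; within the scatter). Both steps stay within the scatter, so neither gives firm ground, and no data yet show whether the ethoxy step holds when that methyl is present. A step of similar size towards a higher number is therefore expected, not clearly beyond the scatter, and the estimate is a 1.9-fold higher number from compound 3 to compound 4 (0.29 log units; within the scatter). For compound 4 the estimated value in this assay is 4100 nM, with an expected range of 1900 nM to 8800 nM.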

Compound 4, half-maximal inhibitory concentration: 4020 nM
Beside the measured number, compound 4's estimate is 1.0-fold (0.01 log units) above it, and the stated range covers the measured number.
By their numbers in this assay, from the lowest: compounds 3, 4, 1 and 2 (each within the scatter of the next, the first and the last beyond it).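

The ethoxy change now has a second instance, on a core carrying the methyl on the aromatic nitrogen, giving a 1.9-fold higher number from compound 3 to compound 4 (0.28 log units; within the scatter) in this assay, so the step keeps its size with that methyl present: the same change on two cores in this assay, a 2.0-fold higher number (0.30 log units; within the scatter) from compound 1 to compound 2 and a 1.9-fold higher number (0.28 log units; within the scatter) from compound 3 to compound 4, 1.1-fold (0.02 log units) apart, within the scatter of two such steps. Within the data shown here, the methyl change has likewise been read on a second core, the one carrying the ethoxy, giving a 2.0-fold lower number from compound 2 to compound 4 (0.31 log units; beyond the scatter), and this modest step is the first for that change to lie beyond the scatter, although its size matches the earlier one: the same change on two cores in this assay, a 1.9-fold lower number (0.28 log units; within the scatter) from compound 1 to compound 3 and a 2.0-fold lower number (0.31 log units; beyond the scatter) from compound 2 to compound 4, 1.1-fold (0.02 log units) apart, within the scatter of two such steps. Across these four compounds, each of the two changes therefore leaves the step of the other essentially unaltered, and the compounds show no sign that the ethoxy and the methyl interfere with each other.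

Both ethoxy steps remain within the scatter, so the compounds shown do not settle whether ethoxy on this aromatic carbon, para to a large group, truly differs from hydrogen. They also leave open how a longer chain such as butoxy, an amine or a carboxylic acid at the same place would behave, and whether any of these would give a step clearly beyond the scatter.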